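Methylsulfonyl for Benzyloxy: Expected Cytotoxicity of Compound 4

This account rests on a few compounds, and the source may have more. Where it says the series, first, only, none or still open, it means among the compounds named here.

Three compounds sharing one core were tested in an ADME assay on BJ cells (Homo sapiens) for cytotoxicity, read by CellTiter-Glo and resazurin assay, with a stated time of 72 h; on this read-out higher numbers stand for an effect only at larger amounts of compound and lower numbers for an effect already at smaller amounts. Compound 1 `CC(C)N(Cc1cccc(OCCCCCC(=O)O)c1)C(=O)c1ccc(-c2ccoc2)cc1` carries a furan-3-yl group; in this assay compound 1 reaches only the limit of > 26000 nM. Compound 3 `CC(C)N(Cc1cccc(OCCCCCC(=O)O)c1)C(=O)c1ccc(-c2ccc(Cl)c(Cl)c2)cc1` carries 3,4-dichlorophenyl instead; compound 3 likewise stops at the limit of > 26000 nM. The step from compound 1 to compound 3 is accordingly a step that the two limits leave unreadable from compound 1 to compound 3. Compound 2 `CC(C)N(Cc1cccc(OCCCCCC(=O)O)c1)C(=O)c1ccc(-c2cccc(OCc3ccccc3)c2)cc1` bears a benzyloxy group on the outer ring; compound 2 too gives only the limit of > 26000 nM. Compound 2 therefore stands where the other two stand, all three resting at the limit of > 26000 nM in this assay, at which 3 of the 3 values shown sit.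

The unmeasured compound 4 `CC(C)N(Cc1cccc(OCCCCCC(=O)O)c1)C(=O)c1ccc(-c2cccc(S(C)(=O)=O)c2)cc1` differs from compound 2 in a single place: methylsulfonyl in place of benzyloxy on an aromatic carbon. Among the measured compounds shown here, no measured step speaks to this exchange, and the one step recorded, from compound 1 to compound 3, has no readable size, so it offers no scale for the change. What the data do show is that every variation of the outer ring so far has left this assay at its limit. For compound 4 the expected step is a step that the limit leaves unreadable from compound 2 to compound 4, none beyond the scatter. Compound 4 is estimated at 40000 nM, in the range from 20000 nM to 100000 nM, most probably again reported only as a limit.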

Compound 4, half-maximal effective concentration: > 26000 nM
Compound 4: only a limit was reported; the forecaster's own chance of this, stated with the estimate: 85%; the middle value lies beyond the limit too.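

No step from compound 1, compound 2 or compound 3 to compound 4 can be read in this assay, since all four compounds rest at one limit: the limit of > 26000 nM in this assay, at which 4 of the 4 values shown sit.

The compounds shown leave open at what concentration, if any, each would reach its half-maximal effect, and whether exchanging the group on the outer ring changes that concentration at all.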